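The compounds below may be only part of what the source reports. "The series", "measured", "known", "first", "only" and "open" are said of these compounds alone.

Of the compounds shown here, three have numbers so far in a functional assay on MCF7 cells (Homo sapiens) for cytotoxicity, read by sulforhodamine B assay, with a stated time of 48 h; on this read-out lower numbers stand for stronger inhibition of growth and higher numbers for weaker inhibition of growth. Compound 1 (`Cc1nn(-c2ccccc2)c(Oc2ccc(-c3nc4cc([N+](=O)[O-])ccc4[nH]3)cc2)c1/C=N/NC(N)=O`) stands at 13800 nM and compound 2 (`Cc1nn(-c2ccccc2)c(Sc2ccc(-c3nc4cc([N+](=O)[O-])ccc4[nH]3)cc2)c1/C=N/NC(N)=O`) stands at 16600 nM while compound 3 (`COc1ccc(N/N=C/c2c(C)nn(-c3ccccc3)c2Oc2ccc(-c3nc4cc(C(N)=O)ccc4[nH]3)cc2)cc1`) stands at 13600 nM on the same read-out. Compound 3 therefore sits together with the other two: all three values lie within the scatter of one another, and no order can be drawn among them.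

The next entry is compound 4 (`Cc1nn(-c2ccccc2)c(Oc2ccc(-c3nc4cc(C(N)=O)ccc4[nH]3)cc2)c1/C=N/NC(N)=O`). Its difference from compound 3 is carbamoyl in place of 4-methoxyphenyl on an amine nitrogen and this amounts to carbamoyl in place of 4-methoxyphenyl on an amine nitrogen. For the measured compounds named here, no measured pair isolates this change, so its size cannot be read directly from the data. The nearest reference is compound 1, which carries the same carbamoyl on that amine nitrogen and gives 13800 nM within the scatter of the value for compound 3. On that basis, no step beyond the scatter is expected in this assay in either direction. The expected change is a 1.1-fold higher number from compound 3 to compound 4 (0.04 log units; within the scatter) and this estimate stays within the scatter. The estimated value for compound 4 is 15000 nM with an expected range from 7500 nM to 30000 nM for the measurement.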

Compound 4, concentration for 50% growth inhibition: 6500 nM
For compound 4 the middle estimate is 2.3-fold (0.36 log units) above the measured one, and the stated range ends above it.
By their numbers in this assay, from the lowest: compound 4; then compounds 3, 1 and 2 (each within the scatter of the next).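

In this assay, for the compounds shown here, the change from 4-methoxyphenyl to carbamoyl on the amine nitrogen gives a 2.1-fold lower number from compound 3 to compound 4 (0.32 log units; beyond the scatter) as one of the first two steps beyond the scatter, so the group on that nitrogen can shift the number when the aromatic carbon of the core carries carbamoyl. Going by these compounds alone, the second is the change from nitro to carbamoyl on the aromatic carbon, which gives a 2.1-fold lower number from compound 1 to compound 4 (0.33 log units; beyond the scatter) when the amine nitrogen carries carbamoyl, whereas compound 1 and compound 3, each with only one of these carbamoyl groups, stayed within the scatter of each other; the lower number therefore appears here only in compound 4, where both places carry carbamoyl. No measurement is at hand to explain either step.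

Still open, going by these compounds, is whether the two places act together beyond this single compound, and whether a sulfur link in place of the oxygen link keeps the number of compound 4 in this assay. Also open, on these data alone, is how a carboxylic acid or an amine on that aromatic carbon, or a short alkyl chain on the amine nitrogen, would compare with carbamoyl.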